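Fluoro for Methyl on a Sulfonamide Phosphatase Inhibitor

The source may report more compounds than this note shows. Statements on the series, on what has been measured and on what is new or still open speak of the compounds shown alone.

Going by the values given here, in an assay on isolated protein for inhibition of alkaline phosphatase, tissue-nonspecific isozyme (Bos taurus), read by chemiluminescence and spectrophotometry (on this read-out higher numbers stand for weaker inhibition and lower numbers for stronger inhibition), compound 2 `Cc1ccc(S(=O)(=O)Nc2ccc(S(N)(=O)=O)cc2)cc1` gives 222000 nM, the highest of the three numbers measured so far. Compound 1 `NS(=O)(=O)c1ccc(NC(=O)c2ccccc2)cc1` gives 70100 nM, a gap beyond the scatter, and compound 3 `Cc1ccc(S(=O)(=O)NCc2ccc(S(N)(=O)=O)cc2)cc1` gives 115 nM, lower by a wide margin. Compound 4 `NS(=O)(=O)c1ccc(NS(=O)(=O)c2ccc(F)cc2)cc1` has not yet been measured in this assay. It differs from compound 2 by fluoro in place of methyl on an aromatic carbon. Among the compounds with values here, no measured pair shows this particular change, so the expectation rests on the single parent value alone. The change is expected to be small, a 1.1-fold lower number from compound 2 to compound 4 (0.05 log units; within the scatter), with no shift beyond the scatter in either direction. Compound 4 is therefore estimated at 200000 nM, with a range from 80000 nM to 500000 nM.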

Compound 4, half-maximal inhibitory concentration: 3260 nM
Compound 4: middle estimate off by 61-fold (1.79 log units), on the high side; measured number below the stated range.
By their numbers in this assay, from the lowest: compound 3; then compound 4; then compound 1; then compound 2.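

In this assay, the change from 4-methylphenyl to 4-fluorophenyl gives a 68-fold lower number from compound 2 to compound 4 (1.83 log units; beyond the scatter), so this place on the aromatic ring, para to a large group, responds strongly to the exchange of one heavy atom for another. The earlier compounds shown here held no step at this place. Nothing available accounts for the size of this step.

The compounds shown leave open how chloro, methoxy or an amine would read at this place. They also leave open whether the same exchange would move compound 3 as far.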